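The source may report more compounds than this note shows. Statements on the series, on what has been measured and on what is new or still open speak of the compounds shown alone.

Measured so far in a functional assay on ileum for inhibition of histamine H1 receptor (Cavia porcellus); a higher number here means a weaker inhibitor, a lower number a stronger inhibitor. Compound 1 `CN1CCN(c2nc3ccccc3n2CCOc2ccccc2)CC1` gives 6.9 nM. Compound 2 `C#CCOCCn1c(N2CCN(C)CC2)nc2ccccc21` gives 12 nM. Compound 3 `CN1CCN(c2nc3ccccc3n2CCOCCO)CC1` gives 42 nM.

Compound 3 stands highest of the three numbers; both steps reaching it, a 6.1-fold higher number from compound 1 to compound 3 (0.78 log units; beyond the scatter) and a 3.5-fold higher number from compound 2 to compound 3 (0.54 log units; beyond the scatter), lie beyond the scatter, whereas a 1.7-fold higher number from compound 1 to compound 2 (0.24 log units; within the scatter) stays within it. Compound 4 `CCSCCCn1c(N2CCN(C)CC2)nc2ccccc21` differs from compound 3 by (ethylsulfanyl)methyl in place of 2-hydroxyethoxy on a saturated chain carbon, two bonds along the chain from an aromatic nitrogen. Among the compounds with values here, the change removes the only hydrogen-bond donor of the side chain, returning to the donor-free pattern shared by compounds 1 and 2, so the steps that bear on it are the two rises into compound 3 read backwards. A modest drop in this assay is expected, landing near compound 2. Compound 4 is therefore expected at 12 nM, with a range of 4 nM to 35 nM, which would mean an expected 3.5-fold lower number from compound 3 to compound 4 (0.54 log units; beyond the scatter).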

Compound 4, half-maximal inhibitory concentration: 530 nM
The estimate for compound 4 lay 44-fold (1.65 log units) below the measured number; measured number outside the range, above it.
By their numbers in this assay, from the lowest: compounds 1 and 2 (each within the scatter of the next); then compound 3; then compound 4.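

At this saturated chain carbon, two bonds along the chain from an aromatic nitrogen, earlier changes were modest at most, whereas this assay now shows a 13-fold higher number from compound 3 to compound 4 (1.10 log units; beyond the scatter), along with a 44-fold higher number from compound 2 to compound 4 (1.65 log units; beyond the scatter) and a 77-fold higher number from compound 1 to compound 4 (1.89 log units; beyond the scatter). Swapping 2-hydroxyethoxy for (ethylsulfanyl)methyl keeps 4 heavy atoms, so an equal heavy-atom count does not preserve the number at this place. No supporting data bear on the cause of this rise.

Sulfur replaces oxygen and the terminal hydroxyl goes in the same step, so their shares remain unseparated. From the compounds shown here alone, a 3-ethoxypropyl chain or a terminal amine remains open here.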